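This account rests on a few compounds, and the source may have more. Where it says the series, first, only, none or still open, it means among the compounds named here.

Working notes on the series. Three compounds share one core: compound 1 `O=C(Nc1nc(-c2ccccc2)cs1)c1ccc([N+](=O)[O-])o1`, compound 2 `COc1cccc(-c2csc(NC(=O)c3ccc([N+](=O)[O-])o3)n2)c1` and compound 3 `CC(C)Oc1cccc(-c2csc(NC(=O)c3ccc([N+](=O)[O-])o3)n2)c1`. In an ADME assay on Vero cells (Chlorocebus sabaeus) for cytotoxicity, read by MTT assay, with a stated time of 72 h (on this read-out lower numbers stand for stronger inhibition and higher numbers for weaker inhibition), compound 1 gives 41700 nM, compound 2 gives 58700 nM and compound 3 gives 69500 nM, the highest of the three numbers, though each step up to it stays within the scatter: a 1.7-fold higher number from compound 1 to compound 3 (0.22 log units; within the scatter) and a 1.2-fold higher number from compound 2 to compound 3 (0.07 log units; within the scatter). Compound 4 `O=C(Nc1nc(-c2cccc(OC3CCCC3)c2)cs1)c1ccc([N+](=O)[O-])o1` differs from compound 3 by cyclopentyl in place of isopropyl on an oxygen on an aromatic ring. The step that bears on it is the earlier enlargement at the oxygen on an aromatic ring, a 1.2-fold higher number from compound 2 to compound 3 (0.07 log units; within the scatter), within the scatter; the two replacements of hydrogen on an aromatic carbon, a 1.4-fold higher number from compound 1 to compound 2 (0.15 log units; within the scatter) and a 1.7-fold higher number from compound 1 to compound 3 (0.22 log units; within the scatter), were likewise within the scatter. No step beyond the scatter is therefore expected in this assay. Compound 4 is expected to give 80000 nM, with a range of 40000 nM to 160000 nM. The expected step is a 1.2-fold higher number from compound 3 to compound 4 (0.06 log units; within the scatter).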

Compound 4, half-maximal inhibitory concentration: 81100 nM
Estimate against measurement, compound 4: 1.0-fold (0.01 log units) below; the range from low to high includes it.
By their numbers in this assay, from the lowest: compounds 1, 2, 3 and 4 (each within the scatter of the next).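

Cyclopentyl is the only group at the oxygen on an aromatic ring that brings a non-aromatic ring, and in this assay this change stays within the scatter, a 1.2-fold higher number from compound 3 to compound 4 (0.07 log units; within the scatter). For the compounds shown here, the larger comparisons also stay within it, a 1.4-fold higher number from compound 2 to compound 4 (0.14 log units; within the scatter) and a 1.9-fold higher number from compound 1 to compound 4 (0.29 log units; within the scatter), so no step among hydrogen, methoxy, isopropoxy and cyclopentyloxy at this place leaves the scatter. Nothing measured here offers an explanation for this.

From the compounds shown here alone, whether an amine or a carboxylic acid carried on a longer chain at this oxygen would give a step beyond the scatter remains open.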